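Cytotoxicity of two pyrimidinone amides and an untested analogue

The source may hold more compounds than are shown below. What is called first, only, known or untested is meant among the compounds shown, and "the series" means these compounds.

Compound 1 `CCCCc1nc(Cl)c(C2NC(=O)NC(C)=C2C(=O)Nc2ccc(F)cc2)[nH]1`: > 10 ug/mL
Compound 2 `CCCCc1nc(Cl)c(C2NC(=O)NC(C)=C2C(=O)Nc2ccccc2[N+](=O)[O-])[nH]1`: "not determined" (no result reported)

In an ADME assay on Vero cells (Chlorocebus sabaeus) for cytotoxicity, read by MTT assay, with a stated time of 72 h (on this read-out higher numbers stand for weaker inhibition and lower numbers for stronger inhibition), compound 1 gives > 10 ug/mL, which is a limit of the assay rather than a number. In this assay compound 2 has "not determined" (no result reported), so there is no single number for it, and the only reading shown for the series is the one described by the limit of > 10 ug/mL in this assay, at which 1 of the 2 values shown sits. Compound 3 `CCCCc1nc(Cl)c(C2NC(=O)NC(C)=C2C(=O)Nc2ccccc2Cl)[nH]1` has not been measured in this assay. It differs from compound 2 by chloro in place of nitro on an aromatic carbon. Among the measured compounds shown here, with no measured step between compound 2 and compound 3, and with compound 1 sitting at the limit described by the limit of > 10 ug/mL in this assay, at which 1 of the 2 values shown sits, the step in this assay is expected to be none beyond the scatter. Compound 3 is therefore estimated at 20 ug/mL, within 8 ug/mL to 60 ug/mL, most likely reported again only as a limit.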

Compound 3, half-maximal inhibitory concentration: 7.6 ug/mL
For compound 3 the middle estimate is 2.6-fold (0.42 log units) above the measured one, outside the stated range (below it).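

In this assay compound 3 gives 7.6 ug/mL, the first actual number shown for an amide of this series. For compound 1, > 10 ug/mL is a limit of the assay and not a number. With 2-chlorophenyl in place of 4-fluorophenyl on the amide-type nitrogen, the reading is an at least 1.3-fold lower number from compound 1 to compound 3 (0.11 log units; that floor lies within the scatter), so this change gives a readable value, but it cannot be said to alter cytotoxicity beyond the usual variation between repeats.

Compound 2 has no result, so any step from it, including the change from nitro to chloro, cannot be read, and nothing measured here gives a cause for the change in reading. On these data alone, whether an amine or a carboxylic acid in place of chloro on the same aromatic carbon would give a number in this assay remains open.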